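Swapping the Aryl Group on a Five-Membered Ring

A few compounds are considered here, and "the series" means these few. Any claim that something is new, unique, unknown or untested is made for them only; others in the source may bear on it.

Compound 1, `COc1cc(C(=O)N/N=C/c2cccc(C(F)(F)F)c2)cc(OC)c1OC`: 51%
Compound 2, `COc1cc(C(=O)N/N=C/c2ccc(C(F)(F)F)cc2)cc(OC)c1OC`: 59.9%
Compound 3, `COc1cc(C2=NN(C(C)=O)C(c3ccccc3F)O2)cc(OC)c1OC`: 13.5%

All three values come from a functional assay on PC-3 cells (Homo sapiens) for antiproliferative activity, read by MTT assay, tested at 1 uM; on this read-out lower numbers stand for a weaker effect and higher numbers for a stronger effect at the one concentration tested. Compound 3 stands lowest of the three, beyond the scatter from both compound 1 and compound 2, so it is the weakest here. Compound 4, `COc1cc(C2=NN(C(C)=O)C(c3ccc(Cl)c([N+](=O)[O-])c3)O2)cc(OC)c1OC`, keeps the core of compound 3 and differs in one place: 4-chloro-3-nitrophenyl in place of 2-fluorophenyl on a saturated ring carbon. Within the data shown here, no measured pair shows this kind of change, and compound 1 and compound 2 differ from compound 3 in their core as well, so nothing anchors the size of the effect. The expected step of a number 6.5 percentage points higher from compound 3 to compound 4 (within the scatter) is small, likely within the scatter. The estimate for compound 4 is 20%, in the range 5% to 45%.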

Compound 4, a percentage reported as inhibition, at one concentration (the size of the read-out at that concentration, not a potency): 43.3%
For compound 4 the middle estimate is 23.3 percentage points below the measured one, within the range that was stated.
By their numbers in this assay, from the lowest: compound 3; then compounds 4, 1 and 2 (each within the scatter of the next, the first and the last beyond it).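

Among these compounds, this is the first pair of compounds that differ only in the aryl group on the saturated ring carbon, and in this assay replacing 2-fluorophenyl with 4-chloro-3-nitrophenyl gives a number 29.8 percentage points higher from compound 3 to compound 4 (beyond the scatter) with the rest of the molecule unchanged. The effect at this position therefore depends on which aryl group it carries. Nothing measured here accounts for this step.

From the compounds shown here alone, it remains open how much of the step belongs to the chlorine and how much to the nitro group, which 4-chlorophenyl and 3-nitrophenyl could separate. Also open, going by these compounds, is whether a simple alkyl chain could replace the aryl ring here.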